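This account rests on a few compounds, and the source may have more. Where it says the series, first, only, none or still open, it means among the compounds named here.

Of the compounds shown here, three built on one shared core have been measured in a functional assay on KOPN-8 cells (Homo sapiens) for antiproliferative activity, with a stated time of 72 h; on this read-out lower numbers stand for an effect already at smaller amounts and higher numbers for an effect only at larger amounts of compound. Compound 1 `COc1ccc(-c2c(Br)c(=O)c3c(OC)cc(OC)cc3n2S(=O)(=O)c2ccc(OC)cc2)cc1` gives 2580 nM, compound 2 `COc1ccc(-c2c(I)c(=O)c3c(OC)cc(OC)cc3n2S(=O)(=O)c2ccc(OC)cc2)cc1` gives 8580 nM, and compound 3 `COc1ccc(-c2cc(=O)c3c(OC)cc(OC)cc3n2S(=O)(=O)c2ccc([N+](=O)[O-])cc2)cc1` gives 17300 nM. Among the measured compounds shown here, the only step between two compounds that differ in a single place, a 3.3-fold higher number from compound 1 to compound 2 (0.52 log units; beyond the scatter), concerns the halogen on the core. Compound 3 carries the highest of the three numbers shown, though its gap to compound 2 lies within the scatter, while its gap to compound 1 lies beyond it. Compound 4 `COc1ccc(-c2cc(=O)c3c(OC)cc(OC)cc3n2S(=O)(=O)c2ccc(C)cc2)cc1` differs from compound 3 in one place: methyl in place of nitro on an aromatic carbon. For the measured compounds named here, no measured step touches the ring that carries the sulfonyl group, so the change from bromo to iodo does not bear on this one, and compounds 1 and 2 differ from compound 3 in two places at once. The expectation for compound 4 therefore rests on little, and a step of a 1.4-fold lower number from compound 3 to compound 4 (0.16 log units; within the scatter) is estimated, with no direction secured beyond the scatter. Compound 4 is estimated at 12000 nM, between 4000 nM and 35000 nM.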

Compound 4, half-maximal effective concentration: > 44800 nM
Compound 4 ended at the assay's limit; the forecaster's own chance of this, stated with the estimate: 10%; at least 3.7-fold (0.57 log units) between middle value and limit.
By their numbers in this assay, from the lowest: compound 1; then compounds 2 and 3 (each within the scatter of the next). At a limit, above all of these: compound 4.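

In this assay, the change from 4-nitrophenyl to 4-methylphenyl gives an at least 2.5-fold higher number from compound 3 to compound 4 (0.41 log units; beyond the scatter), the first step shown at this position, on an aromatic carbon para to a large group. The value of compound 4 is a limit and not a number: the limit of > 44800 nM in this assay, at which 1 of the 4 values shown sits.

Among the compounds shown here, the earlier compounds showed only an exchange of halogen on the core, so this is the first sign that the group at this position matters for the read-out, with nitro giving the lower number of the two.

Going by these compounds, whether an amine or a carboxylic acid at this position would give a number nearer to that of compound 3 or to the limit of compound 4 stays open. Compound 1 and compound 2 carry methoxy here together with a halogen on the core, so they differ from compound 3 and compound 4 in two places and leave the effect of methoxy alone unread.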